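Aryl exchange on a weakly cytotoxic diester

This account rests on a few compounds, and the source may have more. Where it says the series, first, only, none or still open, it means among the compounds named here.

compound 1, `CCOC(=O)c1c(-c2cc3ccccc3oc2=O)nn(-c2ccc(C)c(C)c2)c1C(=O)OCC`: 52000 nM
compound 2, `COC(=O)c1c(-c2cc3ccccc3oc2=O)nn(-c2cccc(Cl)c2)c1C(=O)OC`: 30000 nM

Going by the values given here, in a functional assay on A549 cells (Homo sapiens) for cytotoxicity, read by MTT assay, with a stated time of 48 h (a lower number here means a stronger inhibitor, a higher number a weaker inhibitor), compound 1 gives 52000 nM, the higher of the two numbers measured so far, yet the gap to compound 2, which gives 30000 nM, lies within the usual scatter, so the two compounds are not separated by these data. Compound 3, `CCOC(=O)c1c(-c2cc3ccccc3oc2=O)nn(-c2ccc(Br)cc2)c1C(=O)OCC`, differs from compound 1 in one place: 4-bromophenyl in place of 3,4-dimethylphenyl on an aromatic nitrogen. Among the compounds with values here, no pair of measured compounds shows this change on its own; compound 2 carries both a different aryl group and methyl esters, so it cannot isolate the effect. The step from compound 1 to compound 3 is therefore expected to stay within the scatter, with no clear direction, as a 1.3-fold lower number from compound 1 to compound 3 (0.11 log units; within the scatter). On that basis compound 3 is estimated at 40000 nM, with a range from 15000 nM to 110000 nM.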

Compound 3, half-maximal inhibitory concentration: 100000 nM
For compound 3 the middle estimate is 2.5-fold (0.40 log units) below the measured one, and the stated range covers the measured number.
By their numbers in this assay, from the lowest: compounds 2, 1 and 3 (each within the scatter of the next, the first and the last beyond it).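

Going by these compounds alone, exchanging 3,4-dimethylphenyl for 4-bromophenyl on the aromatic nitrogen gives the first reading of a change at this position alone. It gives a 1.9-fold higher number from compound 1 to compound 3 (0.28 log units; within the scatter) in this assay and so does not separate the two aryl groups, which means that neither the two methyl groups nor the bromine can be read as moving the number in either direction. Nothing available here bears on why these compounds give such numbers.

On these data alone, it remains open whether an aryl group carrying an amine or a carboxylic acid on this nitrogen, or a longer alkyl chain in place of the aryl ring, would move the number beyond the scatter. The role of the esters is also unresolved, since the methyl esters of compound 2 come together with a different aryl group.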